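This account rests on a few compounds, and the source may have more. Where it says the series, first, only, none or still open, it means among the compounds named here.

In a functional assay on RXF 393 cells (Homo sapiens) for inhibition, read by sulforhodamine B assay, with a stated time of 48 h, tested at 0.1 uM (on this read-out lower numbers stand for a stronger effect and higher numbers for a weaker effect at the one concentration tested), compound 3 `COc1cc(Cl)cc(-c2nn(-c3cccc(NC(=O)Nc4cc(C(F)(F)F)cc(C(F)(F)F)c4)c3)cc2-c2ccncc2)c1` gives 101%, the highest of the three numbers recorded. The nearest is compound 1 `O=C(Nc1cccc(-n2cc(-c3ccncc3)c(-c3cc(O)cc(Cl)c3)n2)c1)Nc1ccc(Cl)c(C(F)(F)F)c1`, which in this assay gives 95%, a gap within the scatter; the furthest is compound 2 `O=C(Nc1cccc(-n2cc(-c3ccncc3)c(-c3cc(O)cc(Cl)c3)n2)c1)Nc1ccc(Cl)c(Cl)c1`, which in this assay gives 85%, a gap beyond the scatter. Compound 4 `COc1cc(Cl)cc(-c2nn(-c3cccc(NC(=O)Nc4cccc(C(F)(F)F)c4)c3)cc2-c2ccncc2)c1` differs from compound 3 in one place: hydrogen in place of trifluoromethyl on an aromatic carbon. For the measured compounds named here, one measured step touches that part of the molecule, a number 10 percentage points lower from compound 1 to compound 2 (within the scatter), a move within the scatter. Going by the values given here, no measured step removes a trifluoromethyl group outright, so the expectation rests on that single comparison. Compound 4 is therefore expected to show a step of a number 6 percentage points lower from compound 3 to compound 4 (within the scatter), within the scatter. The estimate for compound 4 in this assay is 95%, ranging from 80% to 106%.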

Compound 4, a percentage reported as activity, at one concentration (the size of the read-out at that concentration, not a potency): 92%
For compound 4 the middle estimate is 3 percentage points above the measured one; the range from low to high includes it.
By their numbers in this assay, from the lowest: compounds 2, 4, 1 and 3 (each within the scatter of the next, the first and the last beyond it).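

In this assay, for the compounds shown here, the earlier compounds showed trifluoromethyl only being exchanged for chloro, whereas here the group is removed outright, leaving hydrogen on the aromatic carbon, with a number 9 percentage points lower from compound 3 to compound 4 (within the scatter). With the other trifluoromethyl group still in place, this position therefore tolerates losing these four heavy atoms without a change beyond the scatter. Nothing available bears on why this step is so small.

On these data alone, it remains open whether an amine or a carboxylic acid at this position would move the read-out beyond the scatter. As far as these compounds go, it is also open whether removing the remaining trifluoromethyl group would do so.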